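The compounds below may be only part of what the source reports. "The series", "measured", "known", "first", "only" and "open" are said of these compounds alone.

Measured so far in a functional assay on NIH3T3 cells for agonist activity at Urotensin-2 receptor (Homo sapiens), with a stated time of 5 days; a higher number here means that more compound is needed for the effect, a lower number that less compound is needed:
- compound 1 `COc1ccc(/C=C/C(=O)NC(CCN(C)C)c2ccc(C)cc2)cc1`: 2000 nM
- compound 2 `Cc1ccc(C(CCN(C)C)NC(=O)CCc2ccc(C(F)(F)F)cc2)cc1`: 2290 nM
- compound 3 `COc1ccc(CCC(=O)NC(CCN(C)C)c2ccc(C)cc2)cc1`: 5370 nM

Compound 1 has the lowest number of the three, though compound 2 sits within the scatter of it; compound 3 gives a clearly higher number than both. Among the compounds with values here, the one single-point step available is a 2.3-fold higher number from compound 2 to compound 3 (0.37 log units; beyond the scatter), a modest change on the saturated-linker pair.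

Compound 4 `Cc1ccc(C(CCN(C)C)NC(=O)/C=C/c2ccc(C(F)(F)F)cc2)cc1` is the counterpart of compound 1 carrying (trifluoromethyl in place of methoxy on an aromatic carbon). Within the data shown here, this is the reverse of the change seen going from compound 2 to compound 3, so a lowering of the number by roughly the same modest amount is expected in this assay, with the caveat that only one such pair exists and it sits on a different linker. Among the measured compounds shown here, no step is available for the alkene-versus-alkane pairs themselves; compound 1 and compound 3 show only what their two values show.

On that basis compound 4 is expected to give about 900 nM in this assay, with a range of 400 nM to 2000 nM, meaning an estimated step of a 2.2-fold lower number from compound 1 to compound 4 (0.35 log units; beyond the scatter).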

Compound 4, half-maximal effective concentration: 437 nM
Compound 4: middle estimate off by 2.1-fold (0.31 log units), on the high side; low and high end bracket the measured number.
By their numbers in this assay, from the lowest: compound 4; then compounds 1 and 2 (each within the scatter of the next); then compound 3.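

Trifluoromethyl in place of methoxy on an aromatic carbon, para to a large group, now has a second reading in this assay: on the core of compound 1 the change gives a 4.6-fold lower number from compound 1 to compound 4 (0.66 log units; beyond the scatter). The direction is the same on both cores, and the sizes do not differ beyond the scatter of two such steps: the same change on two cores in this assay, a 2.3-fold higher number (0.37 log units; beyond the scatter) from compound 2 to compound 3 and a 4.6-fold higher number (0.66 log units; beyond the scatter) from compound 4 to compound 1, 2.0-fold (0.29 log units) apart, within the scatter of two such steps. In both available pairs trifluoromethyl carries the lower number, and neither pair goes against this, although two pairs are a narrow basis.

On these data alone, how a chlorine or a nitrile at this position would compare with methoxy and trifluoromethyl remains open. Also open, as far as these compounds go, is whether the same order would hold on a core with a longer chain in place of the dimethylamino side chain.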